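A few compounds are considered here, and "the series" means these few. Any claim that something is new, unique, unknown or untested is made for them only; others in the source may bear on it.

Measured so far:
Compound 1 `Cc1ccc(-c2nc(=O)s[nH]2)c(-c2ccc([C@@H](C)N(CC3CC3)c3nc(C(=O)NS(=O)(=O)C4CC4)c(C4CC4)s3)cc2)c1` gives 6.5 h in an ADME assay on the whole organism (Macaca fascicularis), at a dose of 1 mg/kg by the oral route; on this read-out lower numbers stand for a shorter-lived compound and higher numbers for a longer-lived compound.
Compound 2 `CONC(=O)c1ccc(C)cc1-c1ccc([C@@H](C)N(CC2CC2)c2nc(C(=O)NS(=O)(=O)C3CC3)c(C3CC3)s2)cc1` gives 5.9 h in this assay.

On the numbers shown, compound 2 sits alongside compound 1: the step of a 1.1-fold lower number from compound 1 to compound 2 (0.04 log units; within the scatter) is within the scatter, so the two cannot be told apart on this read-out. That single step swapped one whole group for another on an aromatic carbon without moving the number. Compound 3 `CNC(=O)c1ccc(C)cc1-c1ccc([C@@H](C)N(CC2CC2)c2nc(C(=O)NS(=O)(=O)C3CC3)c(C3CC3)s2)cc1` differs from compound 2 in one place: methyl in place of methoxy on an amide-type nitrogen. Within the data shown here, no measured step touches this amide-type nitrogen, so the only guide is the general observation that one larger change elsewhere left the read-out unchanged. The expected step of a 1.1-fold lower number from compound 2 to compound 3 (0.03 log units; within the scatter) is therefore small, in no particular direction, and within the scatter. Compound 3 is estimated to give 5.5 h in this assay, with a range from 3 h to 10 h.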

Compound 3, mean residence time: 6.1 h
Compound 3: middle estimate off by 1.1-fold (0.04 log units), on the low side; measured number inside the range.
By their numbers in this assay, from the lowest: compounds 2, 3 and 1 (each within the scatter of the next).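

Methyl in place of methoxy on the amide-type nitrogen gives a 1.0-fold higher number from compound 2 to compound 3 (0.01 log units; within the scatter) in this assay and so leaves the two compounds indistinguishable, the first measured sign that this nitrogen tolerates this small swap without a visible shift in the read-out. The step of a 1.1-fold lower number from compound 1 to compound 3 (0.03 log units; within the scatter) shows that the methylcarbamoyl group, like the methoxycarbamoyl group before it, cannot be told apart from the five-membered ring group of compound 1 on this read-out. No measurement given here offers an explanation for these results.

Only methoxy and methyl are shown on this nitrogen, so it remains open how a longer chain such as ethyl, or a chain carrying an amine or a carboxylic acid, would read. Going by these compounds, it also remains open whether any group at this place can move the number beyond the scatter.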